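Moving a methoxy group from compound 2 to compound 3

This account rests on a few compounds, and the source may have more. Where it says the series, first, only, none or still open, it means among the compounds named here.

Compound 1 `Cc1ccc(Nc2nc(Nc3ccc(N4CCN(C)CC4)cn3)ncc2Cl)cc1` gives 4030 nM in a functional assay on MDA-MB-231 cells (Homo sapiens) for inhibition, read by CCK-8 assay, with a stated time of 48 h; a lower number here means a stronger inhibitor of growth, a higher number a weaker inhibitor of growth
Compound 2 `COc1ccc(Nc2nc(Nc3ccc(N4CCN(C)CC4)cn3)ncc2Cl)cc1` gives 8020 nM in this assay

Among the compounds with values here, compound 2 lies within the scatter of compound 1, the only other compound measured. Compound 3 `COc1cccc(Nc2nc(Nc3ccc(N4CCN(C)CC4)cn3)ncc2Cl)c1` has 3-methoxyphenyl in place of 4-methoxyphenyl on a nitrogen on an aromatic ring. Within the data shown here, the only measured step, a 2.0-fold higher number from compound 1 to compound 2 (0.30 log units; within the scatter), puts methoxy in place of methyl, so it is a loose guide, and no measured step shows this change directly. Since that step stays within the scatter, the expected change is small, an estimated 1.3-fold lower number from compound 2 to compound 3 (0.13 log units; within the scatter) in this assay. Compound 3 is expected at 6000 nM, within an estimated range of 2500 nM to 15000 nM.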

Compound 3, concentration for 50% growth inhibition: 8510 nM
Estimate against measurement, compound 3: 1.4-fold (0.15 log units) below; low and high end bracket the measured number.
By their numbers in this assay, from the lowest: compounds 1, 2 and 3 (each within the scatter of the next, the first and the last beyond it).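

Changing 4-methoxyphenyl to 3-methoxyphenyl gives a 1.1-fold higher number from compound 2 to compound 3 (0.03 log units; within the scatter) in this assay, so these two placings of the methoxy group cannot be told apart here. Set against the 4-methylphenyl of compound 1, the 3-methoxyphenyl gives a 2.1-fold higher number from compound 1 to compound 3 (0.32 log units; beyond the scatter), a modest step that only just clears the usual scatter. Nothing available explains either step. Still open, going by these compounds, is whether a different group on this ring, such as an amine or a carboxylic acid, would move the number further than methyl or methoxy.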